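The source may hold more compounds than are shown below. What is called first, only, known or untested is meant among the compounds shown, and "the series" means these compounds.

Compound 1 `CCN(CC)CCCn1c(=O)c(=Cc2cc(OC)c(OC)c(OC)c2)s/c1=C1\C(=O)Nc2ccc(C)cc21`: in a functional assay on MDA-MB-231 cells (Homo sapiens) for inhibition, read by MTT assay, with a stated time of 72 h (a lower number here means a stronger inhibitor, a higher number a weaker inhibitor), compound 1 reaches only the limit > 200000 nM.
Compound 2 `CCN(CC)CCCn1c(=O)c(=Cc2ccccc2O)s/c1=C1\C(=O)Nc2ccc(Br)cc21`: in this assay compound 2 gives 19900 nM.
Compound 3 `CCN(CC)CCCn1c(=O)c(=Cc2ccc(F)cc2F)s/c1=C1\C(=O)Nc2ccc(Cl)cc21`: in this assay compound 3 reaches only the limit > 200000 nM.

Compound 3 stands at the edge of what this assay can report: its value is a limit, not a number, and it shares that position with compound 1 (the limit of > 200000 nM in this assay, at which 2 of the 3 values shown sit). For the measured compounds named here, compound 2 is the one measured compound that gives a number in this assay.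

Compound 4 `CCN(CC)CCCn1c(=O)c(=Cc2cc(OC)c(OC)c(OC)c2)s/c1=C1\C(=O)Nc2ccc(Cl)cc21` has not been measured. It differs from compound 3 in one place: 3,4,5-trimethoxyphenyl in place of 2,4-difluorophenyl on a double-bonded chain carbon bound to an aromatic carbon. Going by the values given here, the same trimethoxyphenyl group is carried by compound 1, which also sits at the limit, and no step between two measured compounds connects compound 3 to anything with a number.

On that basis no change beyond the scatter is expected from compound 3 to compound 4 in this assay, and the estimated step of a number no higher from compound 3 to compound 4 (the limit leaves the size open) carries little weight because both ends are expected to sit at the limit (the limit of > 200000 nM in this assay, at which 2 of the 3 values shown sit). For compound 4 the expected value in this assay is 200000 nM, with a range from 60000 nM to 600000 nM, and it is expected that the measurement most likely returns only a limit rather than a number.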

Compound 4, half-maximal inhibitory concentration: > 200000 nM
Compound 4 ended at the assay's limit; the forecaster's own chance of this, stated with the estimate: 70%; the middle value sits exactly at the limit.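

No step can be read from compound 3 to compound 4 or from compound 1 to compound 4, as all three compounds end at a limit in this assay and not at a number: the limit of > 200000 nM in this assay, at which 3 of the 4 values shown sit.

The compounds shown leave open how large the effect of any single change is in this assay: no two compounds differing in one place both give a number.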